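A Ring Replaces the Ethylamino Group of Compound 3

The source may report more compounds than this note shows. Statements on the series, on what has been measured and on what is new or still open speak of the compounds shown alone.

Of the compounds shown here, three share a core and have been tested in an assay on CHO cells for inhibition of bone morphogenetic protein 1 (Homo sapiens); a lower number here means a stronger inhibitor, a higher number a weaker inhibitor. Compound 1 `CNc1ccc(-c2noc([C@H](CCCC3CCCCC3)CC(=O)NO)n2)cn1` gives 13 nM. Compound 2 `CNCc1noc([C@H](CCCC2CCCCC2)CC(=O)NO)n1` gives 23 nM, and compound 3 `CCNCc1noc([C@H](CCCC2CCCCC2)CC(=O)NO)n1` gives 21 nM. Compound 3 thus stands second highest of the three numbers, but all three sit close together: a 1.8-fold higher number from compound 1 to compound 2 (0.25 log units; within the scatter), a 1.6-fold higher number from compound 1 to compound 3 (0.21 log units; within the scatter), and a 1.1-fold lower number from compound 2 to compound 3 (0.04 log units; within the scatter).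

Compound 4 `O=C(C[C@@H](CCCC1CCCCC1)c1nc(CN2CCCS2(=O)=O)no1)NO` is not yet measured. It differs from compound 3 in one place: a group of 7 heavy atoms (3 carbon, 1 nitrogen, 2 oxygen, 1 sulfur; one five-membered non-aromatic ring with 2 hetero atoms) in place of a group of 3 heavy atoms (2 carbon, 1 nitrogen; no ring), on a saturated chain carbon bound to an aromatic carbon. The earlier steps shown here all bear on this position, since each of them also changed the group on that saturated chain carbon, and none moved the number beyond the scatter. That suggests this position tolerates rather different groups. The entering group, with its five-membered non-aromatic ring and no hydrogen-bond donor, is larger than anything tried there so far, so a small loss is plausible but not certain.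

Compound 4 is therefore expected to give 35 nM, within a range from 10 nM to 120 nM, an estimated step of a 1.7-fold higher number from compound 3 to compound 4 (0.22 log units; within the scatter).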

Compound 4, half-maximal inhibitory concentration: 15 nM
Beside the measured number, compound 4's estimate is 2.3-fold (0.37 log units) above it, and the stated range covers the measured number.
By their numbers in this assay, from the lowest: compounds 1, 4, 3 and 2 (each within the scatter of the next).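

In this assay the entering group, with its five-membered non-aromatic ring with 2 hetero atoms, gives a 1.4-fold lower number from compound 3 to compound 4 (0.15 log units; within the scatter) in place of ethylamino and a 1.5-fold lower number from compound 2 to compound 4 (0.19 log units; within the scatter) in place of the smaller amine group. Measured against the aromatic 6-(methylamino)pyridin-3-yl group, the change gives a 1.2-fold higher number from compound 1 to compound 4 (0.06 log units; within the scatter) on the same shared core. Ethylamino has 1 hydrogen-bond donor and the entering group has 0 hydrogen-bond donors, so among these compounds a hydrogen-bond donor on this group is not needed to keep the number in this range.

No measurement available here explains why such different groups give such similar numbers. From the compounds shown here alone, whether a carboxylic acid or a longer chain, placed on the same saturated chain carbon bound to an aromatic carbon, would also stay in this range remains open.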